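The source may report more compounds than this note shows. Statements on the series, on what has been measured and on what is new or still open speak of the compounds shown alone.

Measured compounds:
compound 1 `Cc1nc(C)c(C(=O)Oc2ccc(/C=C/C(=O)O)cc2O)nc1C` with 2200 nM
compound 2 `CCOC(=O)/C=C/c1cc(Cl)ccc1OC(=O)c1nc(C)c(C)nc1C` with 36100 nM
compound 3 `CCOC(=O)/C=C/c1ccccc1OC(=O)c1nc(C)c(C)nc1C` with 108000 nM

In a functional assay on EA.hy 926 cells (Homo sapiens) for cytotoxicity, read by MTT assay, with stated times of 24 h and 12 h (on this read-out lower numbers stand for an effect already at smaller amounts and higher numbers for an effect only at larger amounts of compound), compound 1 gives the lowest of the three numbers, both others lying beyond the scatter from it. Compound 4 `CCOC(=O)/C=C/c1ccc(OC(=O)c2nc(C)c(C)nc2C)c(O)c1` is reached from compound 1 by a single change: ethyl in place of hydrogen on an oxygen next to a carbonyl group. Among the measured compounds shown here, the one measured step, a 3.0-fold higher number from compound 2 to compound 3 (0.48 log units; beyond the scatter), concerns a different change and does not bear on this one. What the numbers do show is that compound 2 and compound 3, which already carry the ethyl on that oxygen, give far higher values in this assay than compound 1; but each of them differs from compound 1 in more than one place, so no clean reading of the ethyl alone is available. On this basis a rise of modest size is expected, with wide uncertainty: a 3.6-fold higher number from compound 1 to compound 4 (0.56 log units; beyond the scatter). Compound 4 is therefore estimated at 8000 nM in this assay, with a range from 2500 nM to 30000 nM.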

Compound 4, half-maximal effective concentration: 1700 nM
Compound 4: the middle estimate sits 4.7-fold (0.67 log units) above what was measured; measured number outside the range, below it.
By their numbers in this assay, from the lowest: compounds 4 and 1 (each within the scatter of the next); then compound 2; then compound 3.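

In this assay the step is a 1.3-fold lower number from compound 1 to compound 4 (0.11 log units; within the scatter) and so, on this shared core, the carboxy and ethoxycarbonyl forms cannot be told apart. Among the compounds shown here, this pair gives the first clean reading of ethyl in place of hydrogen on this oxygen, which the earlier compounds could not give, since those carrying the ethyl differ from compound 1 in more than one place. Nothing at hand explains why the two values lie so close.

The compounds shown leave open whether a longer chain such as butyl on this oxygen, or an amide formed with an amine in place of the ester, would also stay within the scatter of compound 1. From the compounds shown here alone, they also rest this reading on a single pair, so whether ethyl on this oxygen reads the same on other cores remains unknown.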